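A few compounds are considered here, and "the series" means these few. Any claim that something is new, unique, unknown or untested is made for them only; others in the source may bear on it.

Measured so far:
compound 1, `CCCC1=C(C(=O)OCC)C(c2cccc([N+](=O)[O-])c2)C(C(=O)OCC)=C(C)N1`: 18 nM
compound 2, `COC(=O)C1=C(C)NC(C)=C(C(=O)OC2C=CCCC2)C1c1cccc([N+](=O)[O-])c1`: 10 nM

Two compounds of the series have numbers in a functional assay on HEK293 cells for antagonist activity at Voltage-dependent L-type calcium channel subunit alpha-1C (Oryctolagus cuniculus), read by FLIPR; on this read-out higher numbers stand for weaker inhibition and lower numbers for stronger inhibition. Compound 1 gives 18 nM. Among the compounds with values here, compound 2 gives 10 nM, the lower of the two numbers; the gap to compound 1 lies within the usual scatter of repeated measurements, so the two cannot be ordered on this evidence, and no step between measured compounds is available for the series.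

Compound 3 `COC(=O)C1=C(C)NC(C)=C(C(=O)OCCc2ccc(Cl)cc2)C1c1cccc([N+](=O)[O-])c1` has not yet been measured. It differs from compound 2 in one place, on an oxygen next to a carbonyl group: 2-(4-chlorophenyl)ethyl in place of cyclohex-2-en-1-yl on an oxygen next to a carbonyl group. The cyclohex-2-en-1-yl group, with its one double bond outside aromatic rings, leaves, and a 2-(4-chlorophenyl)ethyl group with one six-membered aromatic ring enters at the same oxygen; the rest of the shared core is unchanged.

Within the data shown here, with no measured step to lean on, the expected step of a 1.5-fold higher number from compound 2 to compound 3 (0.18 log units; within the scatter) is taken as none beyond the scatter, with the range widened on the weaker side. For compound 3 in this assay the estimate is 15 nM, between 4 nM and 55 nM.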

Compound 3, half-maximal inhibitory concentration: 8 nM
Compound 3: middle estimate off by 1.9-fold (0.27 log units), on the high side, and the stated range covers the measured number.
By their numbers in this assay, from the lowest: compounds 3, 2 and 1 (each within the scatter of the next, the first and the last beyond it).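

Within the data shown here, at the oxygen next to a carbonyl group, this assay now gives the first readable step: a 1.3-fold lower number from compound 2 to compound 3 (0.10 log units; within the scatter). This oxygen therefore carries either 2-(4-chlorophenyl)ethyl, with 9 heavy atoms and one six-membered aromatic ring, or cyclohex-2-en-1-yl, with 6 heavy atoms and one six-membered non-aromatic ring, with no separation between the two beyond the scatter, despite the differences in ring type, chlorine and double bond outside aromatic rings. Nothing measured here offers a reason for this result.

Among these compounds, still open is whether the same holds for 2-phenylethyl without the chlorine, for a longer chain ending in the same ring, or for a chain ending in an amine or a carboxylic acid at this oxygen, since only two groups are compared there so far. Among the compounds shown here, compound 1 differs from compound 2 and compound 3 in more than one place, so no step links it to either, and what its differences contribute remains unresolved.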